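From 5-fluoropyridin-3-yl to 3-fluorophenyl: peak plasma exposure

The source may hold more compounds than are shown below. What is called first, only, known or untested is meant among the compounds shown, and "the series" means these compounds.

- Compound 1 `O=C(Nc1ccc(F)c(-c2nc3ncc(-c4cncc(F)c4)cc3[nH]2)c1)N1CCCC1`: 1070 nM
- Compound 2 `Cc1nc(C)c(C(=O)Nc2ccc(F)c(-c3nc4ncc(-c5ccccc5Cl)cn4n3)c2)o1`: 39300 nM

Of the compounds shown here, two have been measured in an ADME assay on the whole organism (Mus musculus, strain Swiss Webster) for pharmacokinetics, read by LC-MS, at a dose of 50 mg/kg by the oral route; on this read-out lower numbers stand for lower exposure and higher numbers for higher exposure at the dose given. Compound 1 stands lowest of the two at 1070 nM, while compound 2 reaches 39300 nM, a gap well beyond the usual scatter of repeated measurements. The two compounds differ in more than one place, so this gap cannot be tied to any single structural change.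

The next compound, compound 3 `O=C(Nc1ccc(F)c(-c2nc3ncc(-c4cccc(F)c4)cc3[nH]2)c1)N1CCCC1`, stays much closer to compound 1. It carries 3-fluorophenyl in place of 5-fluoropyridin-3-yl on an aromatic carbon, and the rest of the structure is unchanged. Among the compounds with values here, no measured pair shows what this exchange does, so the data offer no direct guide to its size or direction. With nothing to argue for a large move, compound 3 is expected to remain close to compound 1 in this assay, with no shift beyond the scatter. The estimated change is small, a 1.2-fold higher number from compound 1 to compound 3 (0.08 log units; within the scatter). The estimate for compound 3 is 1300 nM, within an expected range of 350 nM to 5000 nM.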

Compound 3, maximal plasma concentration: 7000 nM
Compound 3: middle estimate off by 5.4-fold (0.73 log units), on the low side, and the stated range ends below it.
By their numbers in this assay, from the lowest: compound 1; then compound 3; then compound 2.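

Within the data shown here, exchanging 5-fluoropyridin-3-yl for 3-fluorophenyl on this aromatic carbon gives the first single-place comparison in this assay and produces a 6.5-fold higher number from compound 1 to compound 3 (0.82 log units; beyond the scatter) at this position. The two groups match in heavy-atom count and net charge, and the fluorine stays in the name of both, so what changes in the count is that the ring nitrogen and its hydrogen-bond acceptor leave and a carbon enters; with the rest of the structure unchanged, that exchange alone is enough to move peak plasma exposure beyond the scatter. Nothing measured here explains the step, and this one pair shows only its direction and size at this place.

As far as these compounds go, whether a plain phenyl, or a phenyl ring carrying an amine or a carboxylic acid where the fluorine stands, would keep or lose this higher exposure remains open. Among these compounds, it is also open whether the same exchange would give a step of similar size on a different core, such as that of compound 2, as only one pair speaks to it so far.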